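The compounds below may be only part of what the source reports. "The series", "measured", "known", "first", "only" and "open" are said of these compounds alone.

Measured in a functional assay on MDA-MB-231 cells (Homo sapiens) for antiproliferative activity, read by MTT assay, with a stated time of 72 h; a lower number here means a stronger inhibitor, a higher number a weaker inhibitor:
- compound 1 `CC1=CC[C@H]2[C@H](CC[C@]2(C)O)C(C)(C)[C@@H]1CC[C@H]1[C@]2(C)CC[C@H](OC(=O)c3ccc([N+](=O)[O-])cc3)C(C)(C)O[C@H]2CC[C@@]1(C)O`: 8900 nM
- compound 2 `CC1=CC[C@H]2[C@H](CC[C@]2(C)O)C(C)(C)[C@@H]1CC[C@H]1[C@]2(C)CC[C@H](OC(=O)c3cccc([N+](=O)[O-])c3)C(C)(C)O[C@H]2CC[C@@]1(C)O`: 34700 nM
- compound 3 `CC1=CC[C@H]2[C@H](CC[C@]2(C)O)C(C)(C)[C@@H]1CC[C@H]1[C@]2(C)CC[C@H](OC(=O)c3ccccc3C(F)(F)F)C(C)(C)O[C@H]2CC[C@@]1(C)O`: 31500 nM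

Compound 3 holds the middle place of the three numbers, but that place means little on one side: a 1.1-fold lower number from compound 2 to compound 3 (0.04 log units; within the scatter), so compounds 2 and 3 cannot be told apart. Compound 1 is clearly separated from it, with a 3.5-fold higher number from compound 1 to compound 3 (0.55 log units; beyond the scatter).

Compound 4 `CC1=CC[C@H]2[C@H](CC[C@]2(C)O)C(C)(C)[C@@H]1CC[C@H]1[C@]2(C)CC[C@H](OC(=O)c3ccco3)C(C)(C)O[C@H]2CC[C@@]1(C)O` keeps the shared core and has furan-2-yl in place of 2-(trifluoromethyl)phenyl on a carbonyl carbon.

All three measured steps exchange the group at this same place. The largest is a 3.9-fold higher number from compound 1 to compound 2 (0.59 log units; beyond the scatter), and a 3.5-fold higher number from compound 1 to compound 3 (0.55 log units; beyond the scatter) is of similar, modest size. The data hold no five-membered ring at this place, so they give no direction for this change. Only compound 1, at 8900 nM, shows that a change of this group can reach a clearly lower number. A modest step at most is therefore expected, with a slight lean towards a lower number. The expected step is a 1.5-fold lower number from compound 3 to compound 4 (0.18 log units; within the scatter), and this is an estimate only. For compound 4 the estimated value in this assay is 21000 nM, with an expected range of 8000 nM to 50000 nM.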

Compound 4, half-maximal inhibitory concentration: 14000 nM
Compound 4: the middle estimate sits 1.5-fold (0.18 log units) above what was measured; the range from low to high includes it.
By their numbers in this assay, from the lowest: compounds 1 and 4 (each within the scatter of the next); then compounds 3 and 2 (each within the scatter of the next).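

In this assay the place on the carbonyl carbon now carries a five-membered aromatic ring with 1 hetero atom, and this exchange gives a 2.3-fold lower number from compound 3 to compound 4 (0.35 log units; beyond the scatter) and also a 2.5-fold lower number from compound 2 to compound 4 (0.39 log units; beyond the scatter), so a lower number here does not require a six-membered aromatic ring of carbon only. Against the 4-nitrophenyl group the result is a 1.6-fold higher number from compound 1 to compound 4 (0.20 log units; within the scatter), which leaves compound 1 and compound 4 indistinguishable and shows that two quite different groups reach the same level at this place, while compound 2 and compound 3 stay apart from both. Nothing available explains these differences, and no cause can be assigned to the change of ring or to the drop from 10 heavy atoms to 5.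

As far as these compounds go, it remains open how a thiophene ring, an unsubstituted phenyl ring or a saturated group such as cyclohexyl or a butyl chain would compare on this carbonyl carbon with compound 1 and compound 4. Also open, from the compounds shown here alone, is whether an amine or a carboxylic acid carried on the furan ring would move the number further than the modest steps seen so far.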